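The source may report more compounds than this note shows. Statements on the series, on what has been measured and on what is new or still open speak of the compounds shown alone.

Compound 3 `COC(=O)[C@@]1(C)CCC=C2[C@@H]1CC[C@@H](C)[C@]2(C)Cc1c(C)[nH]c2ccc(C)cc12` gives 28000 nM in a functional assay on WiDr cells (Homo sapiens) for inhibition, read by sulforhodamine B assay, with a stated time of 48 h; a lower number here means a stronger inhibitor of growth, a higher number a weaker inhibitor of growth. Compound 1 `COC(=O)[C@@]1(C)CCC=C2[C@@H]1CC[C@@H](C)[C@]2(C)Cc1c[nH]c2ccc(C)cc12` gives 22000 nM in this assay, and compound 2 `COC(=O)[C@@]1(C)CCC=C2[C@@H]1CC[C@@H](C)[C@]2(C)Cc1c[nH]c2ccc(Br)cc12` gives 20000 nM; compound 3 lies within the scatter of both, so the three numbers cannot be told apart. Compound 4 `COC(=O)[C@@]1(C)CCC=C2[C@@H]1CC[C@@H](C)[C@]2(C)Cc1c(C)[nH]c2ccc(OC)cc12` differs from compound 3 by methoxy in place of methyl on an aromatic carbon. The step that bears most on this change is a 1.1-fold lower number from compound 1 to compound 2 (0.04 log units; within the scatter), which also swapped one group for another on an aromatic carbon; a 1.3-fold higher number from compound 1 to compound 3 (0.10 log units; within the scatter) likewise stayed within the scatter. No change of this kind has yet moved this assay beyond the scatter, so a step of about that size is expected, namely no change at the digits printed from compound 3 to compound 4 (within the scatter). Compound 4 is therefore estimated at 28000 nM, with a range from 12000 nM to 65000 nM.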

Compound 4, concentration for 50% growth inhibition: 17000 nM
For compound 4 the middle estimate is 1.6-fold (0.22 log units) above the measured one; the range from low to high includes it.
By their numbers in this assay, from the lowest: compounds 4, 2, 1 and 3 (each within the scatter of the next).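

At this aromatic carbon, methoxy in place of methyl adds an oxygen and a hydrogen-bond acceptor, and the outcome in this assay is a 1.6-fold lower number from compound 3 to compound 4 (0.22 log units; within the scatter) and nothing more. The position therefore accepts a group with an oxygen as well as methyl and bromo, with no step shown here leaving the scatter. Nothing measured here explains why the numbers stay so close. As far as these compounds go, whether an amine or a carboxylic acid on this carbon would move the number beyond the scatter stays open, as does whether any replacement at this position can do so.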